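The source may hold more compounds than are shown below. What is called first, only, known or untested is meant among the compounds shown, and "the series" means these compounds.

Within the data shown here, in a functional assay on CHO cells for antagonist activity at sphingosine 1-phosphate receptor 2 (Homo sapiens), read by fluorescence and calcium flux, with a stated time of 3 min (a higher number here means a weaker inhibitor, a lower number a stronger inhibitor), compound 3 `Cc1cc(NNC(=O)Nc2cc(Cl)nc(Cl)c2)nc(-c2ccc(F)cc2)c1` gives 1300 nM, the only actual number among the three measured compounds. Compound 1 `Cc1cc(C#N)nc(NNC(=O)Nc2cc(Cl)nc(Cl)c2)c1` gives only a limit, > 6600 nM. Compound 2 `Cc1cc(NNC(=O)Nc2cc(Cl)nc(Cl)c2)nc(-c2cnn(C)c2)c1` likewise gives only a limit, > 2100 nM. Compound 4 `Cc1cc(NNC(=O)Nc2cc(Cl)nc(Cl)c2)nc(C(=O)N(C)C)c1` has not yet been measured; it differs from compound 3 in one place: dimethylcarbamoyl in place of 4-fluorophenyl on an aromatic carbon. Among the measured compounds shown here, two measured steps bear on this change, both leading to the 4-fluorophenyl group that compound 4 gives up. The step of an at least 5.0-fold lower number from compound 1 to compound 3 (0.70 log units; beyond the scatter) shows that 4-fluorophenyl in place of cyano went with a clearly lower number. The step of an at least 1.6-fold lower number from compound 2 to compound 3 (0.20 log units; that floor lies within the scatter) points the same way, though its floor lies within the scatter. Taking the 4-fluorophenyl away again in favour of a dimethylcarbamoyl group is therefore expected to push the number upward, quite possibly back to a limit. The expected step is a 4.6-fold higher number from compound 3 to compound 4 (0.66 log units; beyond the scatter) in this assay. Compound 4 is accordingly estimated at 6000 nM, with a range from 2000 nM to 20000 nM.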

Compound 4, half-maximal inhibitory concentration: > 19000 nM
Compound 4 was reported as a limit; the forecaster's own chance of this, stated with the estimate: 60%; at least 3.1-fold (0.50 log units) between middle value and limit.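

In this assay, dimethylcarbamoyl in place of 4-fluorophenyl gives an at least 14-fold higher number from compound 3 to compound 4 (1.16 log units; beyond the scatter), a large step that shows how much the number at this position, next to the ring nitrogen, can change with one group. Of the four groups shown there, only 4-fluorophenyl gives an actual number, while cyano, 1-methyl-1H-pyrazol-4-yl and dimethylcarbamoyl all end in limits. Compound 4 itself is reported only as a limit: the limit of > 19000 nM in this assay, at which 1 of the 4 values shown sits.

The steps from compound 1 and from compound 2 to compound 4 cannot be read, with limits at both ends, so the order among these three groups stays unknown. Also open, as far as these compounds go, is whether the fluorine or the carbon ring matters for the number, which a plain phenyl or a 4-chlorophenyl group at this position could help to tell.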